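A few compounds are considered here, and "the series" means these few. Any claim that something is new, unique, unknown or untested is made for them only; others in the source may bear on it.

Three compounds of the series have numbers in an assay on RBL-1 cells with Polyunsaturated fatty acid 5-lipoxygenase (Rattus norvegicus) as the target; a higher number here means a weaker inhibitor, a lower number a stronger inhibitor. Compound 1 `CCOc1ccc(Cc2ccc3ccccc3c2O)cc1` gives 62 nM. Compound 2 `Oc1c(Cc2ccc(OCc3ccccc3)cc2)ccc2ccccc12` gives 72 nM. Compound 3 `CSc1ccc(Cc2ccc3ccccc3c2O)cc1` gives 48 nM, the lowest of the three numbers, though its gaps to the other two both stay within the scatter: a 1.3-fold lower number from compound 1 to compound 3 (0.11 log units; within the scatter) and a 1.5-fold lower number from compound 2 to compound 3 (0.18 log units; within the scatter). The remaining step among the measured compounds, a 1.2-fold higher number from compound 1 to compound 2 (0.06 log units; within the scatter), is within the scatter as well.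

Compound 4 `Oc1c(Cc2ccc(Cl)cc2)ccc2ccccc12` has not yet been measured in this assay. It differs from compound 3 in one place: chloro in place of methylsulfanyl on an aromatic carbon. Going by the values given here, the steps that bear on this change are the two that exchange the group on the same aromatic carbon, a 1.3-fold lower number from compound 1 to compound 3 (0.11 log units; within the scatter) and a 1.5-fold lower number from compound 2 to compound 3 (0.18 log units; within the scatter); both are small, and the third step, a 1.2-fold higher number from compound 1 to compound 2 (0.06 log units; within the scatter), which alters the chain attached to that ring, is small too. Each exchange at this ring seen so far has left this assay within the scatter, so no step beyond the scatter is expected here, in either direction. Compound 4 is therefore estimated at 60 nM, with a range from 25 nM to 150 nM. The step this estimate implies, a 1.3-fold higher number from compound 3 to compound 4 (0.10 log units; within the scatter), is expected to stay within the scatter.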

Compound 4, half-maximal inhibitory concentration: 39 nM
Estimate against measurement, compound 4: 1.5-fold (0.19 log units) above, within the range that was stated.
By their numbers in this assay, from the lowest: compounds 4, 3, 1 and 2 (each within the scatter of the next).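

In this assay, methylsulfanyl with its one hydrogen-bond acceptor can give way to chloro with none, on this aromatic carbon para to a large group, for a 1.2-fold lower number from compound 3 to compound 4 (0.09 log units; within the scatter). The earlier groups at this position all reach the ring through oxygen or sulfur, and replacing either of the other two with a lone chlorine atom also stays within the scatter, with a 1.6-fold lower number from compound 1 to compound 4 (0.20 log units; within the scatter) and a 1.8-fold lower number from compound 2 to compound 4 (0.27 log units; within the scatter), so a linking oxygen or sulfur is not needed to remain in the range of compounds 1 to 3. No measured property of these groups is available to account for this result.

As far as these compounds go, whether an amine or a carboxylic acid on this aromatic carbon would stay within the scatter of these four compounds remains open, and so does the result with a plain hydrogen there. Also open, from the compounds shown here alone, is whether the same flat picture across ethoxy, benzyloxy, methylsulfanyl and chloro would hold with a longer chain at this position or with any change to the shared core.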